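This account rests on a few compounds, and the source may have more. Where it says the series, first, only, none or still open, it means among the compounds named here.

Working notes on the series, all read in a functional assay on MCF7 cells (Homo sapiens) for inhibition, read by CCK-8 assay, with a stated time of 48 h; on this read-out lower numbers stand for stronger inhibition and higher numbers for weaker inhibition. Among the measured compounds shown here, compound 2 (`COc1cc(-c2ccnc3cc(-c4ccc5cc[nH]c5c4)nn23)cc(OC)c1OC`) gives 23 nM, the lowest of the two numbers so far. Compound 3 (`COc1cc(-c2ccnc3cc(-c4cn(C(=O)OC(C)(C)C)c5ccccc45)nn23)cc(OC)c1OC`) gives 268 nM, a gap to compound 2 that lies beyond the scatter. Compound 1 (`COc1cc(-c2cc3nccc(-c4cc(OC)c(OC)c(OC)c4)n3n2)cc(OC)c1OC`) reads > 10000 nM, which is a limit of the assay and not a number.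

Next is compound 4 (`COc1ccc(-c2cc3nccc(-c4cc(OC)c(OC)c(OC)c4)n3n2)cc1`), changed from compound 2 on an aromatic carbon of the five-membered aromatic ring with 2 nitrogen: 4-methoxyphenyl in place of 1H-indol-6-yl on an aromatic carbon. This puts 4-methoxyphenyl in place of 1H-indol-6-yl.

For the measured compounds named here, no measured pair isolates this change in this assay, so its size rests on indirect comparison. Going by the values given here, compound 2 alone carries 1H-indol-6-yl, and the only other number, compound 3 at 268 nM, is higher. A shift towards weaker inhibition, beyond the scatter, is therefore expected. The expected change is a 26-fold higher number from compound 2 to compound 4 (1.42 log units; beyond the scatter), as an estimate. For compound 4 the estimated value is 600 nM, with an expected range of 80 nM to 6000 nM.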

Compound 4, half-maximal inhibitory concentration: 125 nM
Beside the measured number, compound 4's estimate is 4.8-fold (0.68 log units) above it; the range from low to high includes it.
By their numbers in this assay, from the lowest: compound 2; then compound 4; then compound 3. At a limit, above all of these: compound 1.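

In this assay, the place on the aromatic carbon of the five-membered aromatic ring with 2 nitrogen now has a first direct step, with 4-methoxyphenyl in place of 1H-indol-6-yl: a 5.4-fold higher number from compound 2 to compound 4 (0.74 log units; beyond the scatter). The entering group has 0 hydrogen-bond donors and one six-membered aromatic ring of carbon only, so neither the indole hydrogen-bond donor nor the five-membered ring is required for compound 4 to give 125 nM. Compound 1, which carries another group at this place, reads > 10000 nM, a limit of the assay and not a number: the limit of > 10000 nM in this assay, at which 1 of the 4 values shown sits.

Going by these compounds, how an amine or a carboxylic acid on that phenyl ring, or a longer alkoxy chain in place of the methoxy, would read remains open. On these data alone, compound 2 and compound 3 differ in more than one place, so the separate contributions of the indole attachment point and the tert-butyl carbamate also remain open.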